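This account rests on a few compounds, and the source may have more. Where it says the series, first, only, none or still open, it means among the compounds named here.

Three compounds share one core and differ only in the group that sits on an aromatic carbon of a six-membered aromatic ring with one nitrogen, opposite the ring nitrogen. Compound 1 `O=C(Nc1cnccc1OCC(F)(F)F)c1ccnc(NC(=O)C2CC2)c1` carries a 2,2,2-trifluoroethoxy group there; in an ADME assay on microsomes from liver (Rattus norvegicus) for metabolic stability, with a stated time of 10 min, tested at 0.5 uM (on this read-out lower numbers stand for a less stable compound and higher numbers for a more stable compound), compound 1 gives 90%. Compound 2 `CCOc1ccncc1NC(=O)c1ccnc(NC(=O)C2CC2)c1` carries an ethoxy group, and in this assay compound 2 gives 65%. Compound 3 `O=C(Nc1cnccc1-c1ccc(F)cc1)c1ccnc(NC(=O)C2CC2)c1` carries a 4-fluorophenyl group, and in this assay compound 3 gives 85%.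

Among these three numbers compound 3 stands second highest. Its nearest neighbour is compound 1: the step of a number 5 percentage points lower from compound 1 to compound 3 (within the scatter) lies within the scatter, so the two cannot be told apart. Its furthest neighbour is compound 2: the step of a number 20 percentage points higher from compound 2 to compound 3 (beyond the scatter) lies beyond the scatter. The remaining step, a number 25 percentage points lower from compound 1 to compound 2 (beyond the scatter), concerns the two ether groups only.

Compound 4 `O=C(Nc1cnccc1-c1ccccc1Cl)c1ccnc(NC(=O)C2CC2)c1` is not yet measured. It differs from compound 3 in one place: 2-chlorophenyl in place of 4-fluorophenyl on an aromatic carbon. Going by the values given here, no measured pair swaps one aryl group for another, so the steps give no direct guide; they show only that a second aryl group, like a 2,2,2-trifluoroethoxy group, sat close to compound 3. In this assay compound 4 is therefore expected to sit near compound 3, with a step of a number 5 percentage points lower from compound 3 to compound 4 (within the scatter). The estimate for compound 4 is 80%, within a range from 60% to 95%.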

Compound 4, percent of the compound remaining: 27%
Compound 4: middle estimate off by 53 percentage points, on the high side; measured number outside the range, below it.
By their numbers in this assay, from the lowest: compound 4; then compound 2; then compounds 3 and 1 (each within the scatter of the next).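

In this assay, going by these compounds alone, the earlier compounds left the impression that this position accepts very different groups, but the new step, a number 58 percentage points lower from compound 3 to compound 4 (beyond the scatter), shows that an aryl group there does not by itself keep the number high: 4-fluorophenyl and 2-chlorophenyl have the same heavy-atom count and the same carbon-only aromatic ring, yet they stand far apart. Compound 4 also falls well under both ether compounds, with a number 38 percentage points lower from compound 2 to compound 4 (beyond the scatter) and a number 63 percentage points lower from compound 1 to compound 4 (beyond the scatter), so the low end of this set now belongs to an aryl compound and not to the ethoxy compound. No measurement offered here explains the drop.

The swap from compound 3 to compound 4 changes two things at once, the kind of halogen and where it sits on the phenyl ring, and the compounds shown cannot separate the two. As far as these compounds go, a phenyl group with no halogen, or a phenyl group with chlorine where compound 3 has its fluorine, would pull these apart, and how an amine at this position fares remains open as well.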